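This account rests on a few compounds, and the source may have more. Where it says the series, first, only, none or still open, it means among the compounds named here.

In an ADME assay on WI-38 cells (Homo sapiens) for cytotoxicity, read by MTT assay, with a stated time of 3 days (a higher number here means a weaker inhibitor, a lower number a stronger inhibitor), compound 1 `CCCCCCCCC#Cc1cn(C/C=C\CN2C(=O)c3ccccc3C2=O)c(=O)[nH]c1=O` gives 49000 nM, compound 2 `CCCCCCCCC#Cc1cn(C/C=C/CN2C(=O)c3ccccc3C2=O)c(=O)[nH]c1=O` gives 53000 nM and compound 3 `CCCCCC#Cc1cn(C/C=C/CN2C(=O)c3ccccc3C2=O)c(=O)[nH]c1=O` gives 40000 nM. These three numbers all lie within the scatter of one another, so compound 1 stands in a single unseparated group. Compound 4 `CCCCC#Cc1cn(C/C=C\CN2C(=O)c3ccccc3C2=O)c(=O)[nH]c1=O` has yet to be measured, and its difference from compound 1 is hydrogen in place of butyl on a saturated chain carbon, four bonds along the chain from a triple-bonded carbon. Within the data shown here, two measured steps bear on this change. The first concerns (the fact that compounds 1 and 2 differ only in the configuration as drawn), and that change gave a 1.1-fold higher number from compound 1 to compound 2 (0.03 log units; within the scatter), within the scatter. The second is a change of the same kind, hydrogen in place of propyl, which gave a 1.3-fold lower number from compound 2 to compound 3 (0.12 log units; within the scatter), also within the scatter. Neither step suggests a large effect, so no shift beyond the scatter is expected in this assay, with at most a slight drift toward a lower number. The expected change is a 1.3-fold lower number from compound 1 to compound 4 (0.10 log units; within the scatter). The estimated value for compound 4 is 39000 nM. Its expected range runs from 21000 nM to 72000 nM.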

Compound 4, half-maximal inhibitory concentration: 28000 nM
Beside the measured number, compound 4's estimate is 1.4-fold (0.14 log units) above it; measured number inside the range.
By their numbers in this assay, from the lowest: compounds 4, 3, 1 and 2 (each within the scatter of the next).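

In this assay the change to hydrogen in place of butyl, four bonds along the chain from a triple-bonded carbon, can now be read on the double bond drawn Z, where it gives a 1.8-fold lower number from compound 1 to compound 4 (0.24 log units; within the scatter). The earlier shortening step, a 1.3-fold lower number from compound 2 to compound 3 (0.12 log units; within the scatter), stood on the double bond drawn E, so in these two pairs a shorter chain stays within the scatter with either drawing of the double bond. Nothing at hand gives a cause for the step from compound 1 to compound 4.

The compounds shown leave open whether a longer chain, or an amine or a carboxylic acid at the end of the chain, would move the number beyond the scatter. They also leave open whether any change at this position would separate a pair in this assay at all.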